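The compounds below may be only part of what the source reports. "The series", "measured", "known", "first", "only" and "open" are said of these compounds alone.

Measured so far:
- Compound 1 `COc1cc(C[C@@H](O)[C@@H]2C[C@@H](O)[C@@H](c3cc(OC)c(O)c(OC)c3)[C@H](c3ccc(O)c(OC)c3)O2)ccc1O` gives 23600 nM in a functional assay on RAW264.7 cells (Mus musculus) for inhibition, read by Griess assay, with stated times of 1 h and 24 h; on this read-out lower numbers stand for stronger inhibition and higher numbers for weaker inhibition
- Compound 2 `COc1cc(CC[C@H]2C[C@H](O)[C@H](O)[C@@H](c3ccc(O)c(OC)c3)O2)ccc1O` gives > 50000 nM in this assay (a limit)

Compound 1 has a measured number (23600 nM) in this assay and the series has no other. Compound 2 stands at > 50000 nM in this assay and that value is a limit of the assay, not a number. The next case is compound 3 `COc1cc(CC[C@H]2C[C@H](O)[C@@H](O)[C@@H](c3ccc(O)c(OC)c3)O2)ccc1O` and its relation to compound 2 is this: (the two compounds have the same atoms and bonds and differ only in configuration as drawn: 1 of 4 stereo elements differ; a stereocentre at a saturated ring carbon is drawn S in compound 2 and R in compound 3). Among the measured compounds shown here, no measured pair shows what such a change does in this assay. The expectation for compound 3 therefore rests on compound 2 (> 50000 nM) alone, and that value is a limit. No change beyond the scatter is expected, and compound 3 may well also report only a limit. The estimated step (an at least 1.1-fold lower number from compound 2 to compound 3 (0.04 log units; that floor lies within the scatter)) is expected to lie within the usual scatter, in no clear direction. For compound 3 the estimate is 45000 nM with an expected range from 20000 nM to 100000 nM as the likely span.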

Compound 3, half-maximal inhibitory concentration: 21800 nM
Compound 3: the middle estimate sits 2.1-fold (0.31 log units) above what was measured, and the stated range covers the measured number.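

Configuration at this saturated ring carbon is the first change in the series with a readable effect. In this assay, the S to R change gives an at least 2.2-fold lower number from compound 2 to compound 3 (0.36 log units; beyond the scatter), so the drawn configuration at this position alone is enough to move the read-out beyond the scatter. Compound 2 stands at > 50000 nM, and that value is a limit. The step can be assigned to this one stereocentre because nothing else changes between the two compounds: the fact that compounds 2 and 3 differ only in the configuration as drawn.

Going by these compounds, the true size of the step stays open, as only its floor can be read: the limit of > 50000 nM in this assay, at which 1 of the 3 values shown sits. Also open, on these data alone, is whether an amine or a carboxylic acid on this ring carbon would keep the read-out of compound 3, and whether the other stereocentres respond in the same way.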